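This account rests on a few compounds, and the source may have more. Where it says the series, first, only, none or still open, it means among the compounds named here.

In a functional assay on K562 cells (Homo sapiens) for inhibition, read by trypan blue exclusion, with a stated time of 72 h (on this read-out lower numbers stand for stronger inhibition and higher numbers for weaker inhibition), compound 1 (`Cn1c(=O)c(S(=O)(=O)c2ccc(F)cc2F)cc2cnc(Nc3ccc4[nH]c(C(=O)O)cc4c3)nc21`) gives 10000 nM and so stands within the scatter of both of its measured relatives. Compound 2 (`Cn1c(=O)c(S(=O)(=O)c2ccc(F)cc2)cc2cnc(Nc3ccc4occc4c3)nc21`) gives 5000 nM and compound 3 (`O=c1c(S(=O)(=O)c2ccc(F)cc2F)cc2cnc(Nc3ccc4[nH]ccc4c3)nc2n1C1CCCC1`) gives 5000 nM in this assay as well. Compound 4 (`Cn1c(=O)c(S(=O)(=O)c2ccc(F)cc2F)cc2cnc(Nc3cccc4[nH]ccc34)nc21`) differs from compound 1 in one place, on a nitrogen on an aromatic ring, with 1H-indol-4-yl in place of 2-carboxy-1H-indol-5-yl (1H-indol-4-yl in place of 2-carboxy-1H-indol-5-yl on a nitrogen on an aromatic ring). Among the compounds with values here, no measured pair differs in one place, so the evidence for this change is thin. Within the data shown here, compound 3, which has no carboxy group, gives 5000 nM and offers the only loose guide, alongside compound 2. A small step toward a lower number is therefore expected in this assay (a 2.5-fold lower number from compound 1 to compound 4 (0.40 log units; beyond the scatter)). Compound 4 is estimated at 4000 nM (expected range 1000 nM to 10000 nM).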

Compound 4, half-maximal inhibitory concentration: 1500 nM
Compound 4: the middle estimate sits 2.7-fold (0.43 log units) above what was measured, within the range that was stated.
By their numbers in this assay, from the lowest: compound 4; then compounds 2, 3 and 1 (each within the scatter of the next).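

In this assay, within the data shown here, putting 1H-indol-4-yl in place of 2-carboxy-1H-indol-5-yl on a nitrogen on an aromatic ring gives a 6.7-fold lower number from compound 1 to compound 4 (0.82 log units; beyond the scatter), the only step here that can be read. It shows that the group at this place can shift the number beyond the scatter, with the shared core unchanged. No measurement shown explains the shift.

The change both removes the carboxy group and alters the point of attachment, and the compounds shown do not separate the two. From the compounds shown here alone, how an amine or a carboxamide would behave on the indole also remains open.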